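This account rests on a few compounds, and the source may have more. Where it says the series, first, only, none or still open, it means among the compounds named here.

Measured so far:
compound 1 `Cc1nc2c(CCc3ccccc3)cccn2c1N` — 47%
compound 2 `Cc1nc2c(OCc3ccccc3)cccn2c1CN` — 46%

In a functional assay on the whole organism with Rattus norvegicus as the target, at a dose of 40 mg/kg by the intraperitoneal route (a lower number here means less inhibition, a higher number more inhibition at the dose given (going by the name of the read-out)), compound 1 gives 47%, the higher of the two numbers, though compound 2 with 46% lies within the scatter of it, so the two show no real difference. Compound 3 `CC(=O)Nc1c(C)nc2c(CCc3ccccc3)cccn12` has not yet been measured. It differs from compound 1 by acetyl in place of hydrogen on a nitrogen on an aromatic ring. For the measured compounds named here, no step between measured compounds is known here, so the change rests on no precedent. The step of a number 7 percentage points lower from compound 1 to compound 3 (within the scatter) is expected to be small, at most a modest loss, and may fall within the scatter. Compound 3 is estimated at 40%, between 20% and 60%.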

Compound 3, a percentage reported as inhibition, in the whole organism at one dose (the size of the read-out at that dose, not a potency): 40%
The estimate for compound 3 equals the measured number at the digits printed, and the stated range covers the measured number.
By their numbers in this assay, from the lowest: compounds 3, 2 and 1 (each within the scatter of the next).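

In this assay, the change from amino to acetamido gives a number 7 percentage points lower from compound 1 to compound 3 (within the scatter). For the compounds shown here, this is the first single-place comparison, and it shows that the nitrogen on the aromatic ring can carry acetyl in place of hydrogen without a shift beyond the scatter. No measurement available here bears on why the read-out responds in this way. The compounds shown leave open whether a methyl, a benzoyl or a longer acyl chain on this nitrogen would fit the same picture. They also leave open whether acetyl would behave alike on the aminomethyl group of compound 2.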